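A few compounds are considered here, and "the series" means these few. Any claim that something is new, unique, unknown or untested is made for them only; others in the source may bear on it.

In a functional assay on HepG2 cells (Homo sapiens) for antiproliferative activity, read by MTT assay, with a stated time of 24 h (a lower number here means a stronger inhibitor, a higher number a weaker inhibitor), compound 1 `Cc1ccc(-c2nn(-c3ccccc3)cc2-c2nc3ccccc3n2S(=O)(=O)c2ccc(C)cc2)cc1` gives 520 nM. Compound 2 `Cc1ccc(-c2nn(-c3ccccc3)cc2-c2nc3ccccc3n2S(=O)(=O)c2ccc(Cl)cc2)cc1`, with chloro in place of methyl, gives 5520 nM, and this is an 11-fold higher number from compound 1 to compound 2 (1.03 log units; beyond the scatter), a large step. Compound 3 `Cc1ccc(-c2nn(-c3ccccc3)cc2-c2nc3ccccc3n2S(=O)(=O)c2ccc(Br)cc2)cc1`, with bromo in place of methyl, gives 3040 nM, and this is a 5.8-fold higher number from compound 1 to compound 3 (0.77 log units; beyond the scatter), a modest step. Compound 3 thus stands well on the weaker side of compound 1, but a 1.8-fold lower number from compound 2 to compound 3 (0.26 log units; within the scatter) means it cannot be told apart from compound 2.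

Compound 4 `Cc1ccc(-c2nn(-c3ccccc3)cc2-c2nc3ccccc3n2S(=O)(=O)c2ccc(C(F)(F)F)cc2)cc1` keeps the shared core and changes one group: trifluoromethyl in place of bromo on an aromatic carbon. Among the measured compounds shown here, no measured step involves trifluoromethyl, so the evidence is indirect. The nearest guide is the exchange of chloro for bromo, a 1.8-fold lower number from compound 2 to compound 3 (0.26 log units; within the scatter), while the steps away from methyl in compound 1 show that this position can matter. The expected change in this assay is therefore none beyond the scatter, and the direction is open, with a 1.2-fold higher number from compound 3 to compound 4 (0.06 log units; within the scatter) as the estimated step. For compound 4 the estimated value is 3500 nM, within a range of 1200 nM to 9000 nM.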

Compound 4, half-maximal inhibitory concentration: 1930 nM
Estimate against measurement, compound 4: 1.8-fold (0.26 log units) above; the measured number falls inside the stated range.
By their numbers in this assay, from the lowest: compound 1; then compounds 4, 3 and 2 (each within the scatter of the next, the first and the last beyond it).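

In this assay, among the compounds shown here, trifluoromethyl is the first group at this position that separates from one of the halogens: a 2.9-fold lower number from compound 2 to compound 4 (0.46 log units; beyond the scatter) lies beyond the scatter, whereas a 1.6-fold lower number from compound 3 to compound 4 (0.20 log units; within the scatter) stays within it, so compound 4 cannot be told apart from compound 3. Methyl still gives the lowest number of the set, as a 3.7-fold higher number from compound 1 to compound 4 (0.57 log units; beyond the scatter) shows, so all three replacements of methyl leave a higher number, but the size of that rise varies with the group. Nothing measured here explains why these groups differ from methyl or from one another.

The compounds shown carry only methyl, chloro, bromo or trifluoromethyl at this position, so it remains open whether an amine, a methoxy group or a longer alkyl chain would give a number lower than that of compound 1. Going by these compounds, it also remains open whether the same order would hold if the rest of the shared core were changed, as it is identical in all four compounds.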